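This account rests on a few compounds, and the source may have more. Where it says the series, first, only, none or still open, it means among the compounds named here.

Of the compounds shown here, three have been measured in a physicochemical assay for solubility, in phosphate buffer, measured as kinetic solubility, with a stated time of 1 h, at pH 7.4; on this read-out lower numbers stand for lower solubility and higher numbers for higher solubility. Compound 1 `Cc1cc(C)cc(NC(=O)COc2cc(C)nc3ccccc23)c1` gives 55000 nM in this assay. Compound 2 `COc1ccc2nc(C)cc(NC(=O)C(=O)Nc3cc(C)cc(C)c3)c2c1` gives 10000 nM. Compound 3 `COc1ccc2nc(C)cc(OCC(=O)Nc3cc(C)ccc3C)c2c1` gives 45500 nM, the second highest of the three numbers; its gap to compound 1 lies within the scatter, so the two cannot be told apart, while compound 2 sits clearly lower, beyond the scatter. The next compound, compound 4 `COc1ccc2nc(C)cc(OCC(=O)Nc3ccc(Cl)c(OC)c3)c2c1`, keeps the core of compound 3 and alters only the group on the amide-type nitrogen: 4-chloro-3-methoxyphenyl in place of 2,5-dimethylphenyl on an amide-type nitrogen. Among the compounds with values here, no pair of measured compounds differs in this single place, so nothing measured speaks directly to this change. The expected step is a 1.8-fold lower number from compound 3 to compound 4 (0.26 log units; within the scatter), a modest move downward in this assay, though a result within the scatter of compound 3 would not be surprising. Compound 4 is estimated at 25000 nM, with a range from 8000 nM to 70000 nM.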

Compound 4, solubility: 13000 nM
Beside the measured number, compound 4's estimate is 1.9-fold (0.28 log units) above it; low and high end bracket the measured number.
By their numbers in this assay, from the lowest: compounds 2 and 4 (each within the scatter of the next); then compounds 3 and 1 (each within the scatter of the next).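

Within the data shown here, with the core held fixed, the change to 4-chloro-3-methoxyphenyl in place of 2,5-dimethylphenyl on an amide-type nitrogen gives a 3.5-fold lower number from compound 3 to compound 4 (0.54 log units; beyond the scatter) in this assay and so provides the first single-place comparison. Among these compounds, it shows that the group at this position can by itself move the number beyond the scatter, which the earlier compounds could not show, as no two of them differed in only one place. No supporting measurement is available to explain the step.

The compounds shown leave open whether the chloro or the methoxy group accounts for the step, as the two enter together while both methyl groups leave. They also do not show how an amine or a carboxylic acid on this phenyl ring would read in this assay or whether the step would carry over to the core of compound 1.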